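A few compounds are considered here, and "the series" means these few. Any claim that something is new, unique, unknown or untested is made for them only; others in the source may bear on it.

This account follows a small set of thiourea compounds built on a shared core and tested in an ADME assay on Huh-7 cells (Homo sapiens) for cytotoxicity; on this read-out lower numbers stand for higher toxicity in this test and higher numbers for lower toxicity in this test. Compound 1 `NC(=S)Nc1cccc(OCCCCCN2CCN(c3ccccc3-c3ccccc3)C2=S)c1` belongs to that set. In this assay compound 1 gives > 50000 nM, which is a limit of the assay rather than a number. Within the data shown here, compound 2 `NC(=S)Nc1cccc(OCCCCCNC(=S)Nc2cc(Cl)cc(Cl)c2)c1` gives 18000 nM in this assay, the only plain number among the three measured so far. Compound 3 `NC(=S)Nc1cccc(OCCCCCCCCNC(=S)Nc2ccccc2)c1` carries an anilino group at the far end of its chain. In this assay compound 3 gives > 50000 nM, again a limit of the assay and not a number. As far as these compounds go, compound 3 therefore stands at the limit of > 50000 nM in this assay, at which 2 of the 3 values shown sit, so its exact position is unknown. Compound 4 `CC(C)(C)c1ccc(NC(=S)NCCCCCCCCOc2cccc(NC(N)=S)c2)cc1` differs from compound 3 by tert-butyl in place of hydrogen on an aromatic carbon. Among the measured compounds shown here, no step between two measured compounds shows how such a change acts in this assay. The step expected from compound 3 to compound 4 is an at least 1.1-fold lower number from compound 3 to compound 4 (0.04 log units; that floor lies within the scatter), which is a small move within the usual scatter. Compound 4 is expected to give 45000 nM, within a range from 15000 nM to 120000 nM.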

Compound 4, half-maximal cytotoxic concentration: 17000 nM
Compound 4: the middle estimate sits 2.6-fold (0.42 log units) above what was measured; measured number inside the range.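

In this assay, tert-butyl in place of hydrogen on the aromatic ring at the far end of the chain, para to a large group, gives an at least 2.9-fold lower number from compound 3 to compound 4 (0.46 log units; beyond the scatter). Among these compounds, this is the first step in the set that can be read, and it shows that this position is not indifferent: the change goes with higher toxicity in this test. The true size of the step remains unknown, because compound 3 stands at a limit of the assay rather than at a number: the limit of > 50000 nM in this assay, at which 2 of the 4 values shown sit.

As far as these compounds go, whether a methyl group, an amine or a carboxylic acid at the same place would move the number in the same direction remains open. The step also rests on a single pair of compounds, so it is unclear whether tert-butyl would do the same on a shorter chain.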